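The compounds below may be only part of what the source reports. "The series", "measured", "known", "first", "only" and "open" are said of these compounds alone.

In a functional assay on HT-29 cells (Homo sapiens) for cytotoxicity, read by MTT assay, with a stated time of 72 h (a higher number here means a weaker inhibitor of growth, a lower number a stronger inhibitor of growth), compound 3 `O=C(/N=C(/NC(=O)c1ccno1)[Se]Cc1ccccc1)c1ccno1` gives only a limit of the assay, > 100000 nM. Compound 1 `CS/C(=N\C(=O)c1ccno1)NC(=O)c1ccno1` likewise stops at the limit, > 100000 nM. Compound 2 `C[Se]/C(=N\C(=O)c1ccco1)NC(=O)c1ccco1` also reaches only the limit, > 100000 nM. All three values sit at the limit of > 100000 nM in this assay, at which 3 of the 3 values shown sit, so the step that the two limits leave unreadable from compound 1 to compound 3 cannot be read. Compound 4 `C[Se]/C(=N\C(=O)c1ccno1)NC(=O)c1ccno1` differs from compound 3 by hydrogen in place of phenyl on a saturated chain carbon bound to a selenium atom; cut one bond further out, the change reads benzyl to methyl. Going by the values given here, the only measured step that touches this change, a step that the two limits leave unreadable from compound 1 to compound 3, is unreadable, and compound 2 offers no number either, so no direction can be drawn. Compound 4 is therefore expected to remain at the limit, estimated at 150000 nM with a range of 30000 nM to 1000000 nM, an expected step that the limit leaves unreadable from compound 3 to compound 4.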

Compound 4, concentration for total growth inhibition: > 100000 nM
Compound 4 ended at the assay's limit; the forecaster's own chance of this, stated with the estimate: 85%; the middle value is on the limit's open side.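

The steps linking compound 1, compound 3 and compound 4 in this assay cannot be read, because each value is a limit and not a number: the limit of > 100000 nM in this assay, at which 4 of the 4 values shown sit. The compounds shown leave open which change to the shared core, if any, would give a measurable value.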